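A few compounds are considered here, and "the series" means these few. Any claim that something is new, unique, unknown or untested is made for them only; others in the source may bear on it.

Measured so far in this series:
compound 1 `COc1ccc(C2=C(c3cc(OC)c(OC)c(OC)c3)C(=O)CC2O[SiH2]C(C)(C)C)cc1`: > 100 ug/mL
compound 2 `COc1ccc(C2=C(c3cc(OC)c(OC)c(OC)c3)CC(O)C2=O)cc1[N+](=O)[O-]`: > 100 ug/mL
compound 3 `COc1ccc(C2=C(c3cc(OC)c(OC)c(OC)c3)C(=O)CC2O)cc1`: 10 ug/mL

In an ADME assay on HEK293 cells (Homo sapiens) for cytotoxicity, read by MTT assay, with a stated time of 72 h (on this read-out lower numbers stand for stronger inhibition and higher numbers for weaker inhibition), compound 3 gives 10 ug/mL. Compound 1 reaches only a limit of this assay, > 100 ug/mL. The change a group of 5 heavy atoms (4 carbon, 1 silicon; no ring) in place of a hydrogen atom, on an oxygen on a saturated carbon thus produces an at least 10-fold higher number from compound 3 to compound 1 (1.00 log units; beyond the scatter). Compound 2 also sits at a limit, > 100 ug/mL, so the limit of > 100 ug/mL in this assay, at which 2 of the 3 values shown sit, holds for two of the three values. How the core of compound 2 differs from the core of compound 3 is not broken down here.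

Compound 4 `COc1ccc(C2=C(c3cc(OC)c(OC)c(OC)c3)CC(O[SiH2]C(C)(C)C)C2=O)cc1[N+](=O)[O-]` is not yet measured. Its change from compound 2, (a group of 5 heavy atoms (4 carbon, 1 silicon; no ring) in place of a hydrogen atom, on an oxygen on a saturated carbon), is the same change as that from compound 3 to compound 1, at a place described in identical words. The earlier step was an at least 10-fold higher number from compound 3 to compound 1 (1.00 log units; beyond the scatter). Compound 2 already stands at a limit, > 100 ug/mL. Compound 4 is therefore expected to remain at the limit, estimated at 200 ug/mL in this assay. The expected step is a step that the limit leaves unreadable from compound 2 to compound 4, which rests on the two statements above.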

Compound 4, half-maximal inhibitory concentration: > 100 ug/mL
Compound 4 gave a limit, no number; the forecaster's own chance of this, stated with the estimate: 85%; the middle value is on the limit's open side.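

No size can be read for the step between compound 2 and compound 4, since both values are limits: the limit of > 100 ug/mL in this assay, at which 3 of the 4 values shown sit.

The compounds shown leave open whether the change that raised the number on the core of compound 3 does the same on the core of compound 2.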